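The compounds below may be only part of what the source reports. "The series", "measured", "known", "first", "only" and "open" are said of these compounds alone.

Compound 1 is `CCOC(=O)CCC(=O)N1CCN(CCCOc2cc3c(Nc4ccc(F)c(Cl)c4)ncnc3cc2OC)CC1`. Among the measured compounds shown here, in a functional assay on A549 cells (Homo sapiens) for cytotoxicity, read by MTT assay, with a stated time of 24 h, tested at 10 uM (on this read-out higher numbers stand for a weaker effect at the one concentration tested and lower numbers for a stronger effect), compound 1 gives 77.6%, which is the lowest of the three numbers measured so far. Its two companions differ from it only in the group attached at the ester end. Compound 2 is `CCCCCCCOC(=O)CCC(=O)N1CCN(CCCOc2cc3c(Nc4ccc(F)c(Cl)c4)ncnc3cc2OC)CC1` and in this assay compound 2 gives 89.1%. Compound 3 is `CCCCCCCCCOC(=O)CCC(=O)N1CCN(CCCOc2cc3c(Nc4ccc(F)c(Cl)c4)ncnc3cc2OC)CC1` and in this assay compound 3 gives 90%.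

The measured steps show a number 11.5 percentage points higher from compound 1 to compound 2 (beyond the scatter) and a number 12.4 percentage points higher from compound 1 to compound 3 (beyond the scatter), while the step between the two larger compounds is a number 0.9 percentage points higher from compound 2 to compound 3 (within the scatter). Extending the ester end thus moved the number upward once, and the further extension did not move it further.

Compound 4 is `CCCCCCCCCCCCCCOC(=O)CCC(=O)N1CCN(CCCOc2cc3c(Nc4ccc(F)c(Cl)c4)ncnc3cc2OC)CC1`. Compared with compound 1 the change is dodecyl in place of hydrogen on a saturated chain carbon, two bonds along the chain from an oxygen next to a carbonyl group. This is the same kind of change as in the two measured steps, only carried further. Those steps point to a modest upward shift from compound 1 and then a flat stretch, so the expected step is a number 12.4 percentage points higher from compound 1 to compound 4 (beyond the scatter), in the direction of a weaker effect, of about the size seen for compound 2 and compound 3 rather than anything larger. In this assay compound 4 is therefore estimated at 90%, with a range from 81% to 99%.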

Compound 4, a percentage reported as activity, at one concentration (the size of the read-out at that concentration, not a potency): 100%
The estimate for compound 4 lay 10 percentage points below the measured number; measured number above the stated range.
By their numbers in this assay, from the lowest: compound 1; then compounds 2, 3 and 4 (each within the scatter of the next, the first and the last beyond it).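

Carried as far as dodecyl, the change at this position, on a saturated chain carbon two bonds along the chain from an oxygen next to a carbonyl group, gives in this assay a step of a number 22.4 percentage points higher from compound 1 to compound 4 (beyond the scatter), and the flat stretch between the two earlier long chains turns out not to be the whole picture, since a number 10.9 percentage points higher from compound 2 to compound 4 (beyond the scatter), although a number 10 percentage points higher from compound 3 to compound 4 (within the scatter). Lengthening the chain by a pentyl piece gives a similar step from two different starting compounds, which the earlier compounds could not show: the same change on two cores in this assay, a number 11.5 percentage points higher (beyond the scatter) from compound 1 to compound 2 and a number 10 percentage points higher (within the scatter) from compound 3 to compound 4, 1.5 percentage points apart, within the scatter of two such steps. The same holds for a heptyl piece, so within these four compounds the steps add up fairly evenly, with weaker effect as the chain grows, even though neighbouring long chains stay hard to tell apart: the same change on two cores in this assay, a number 12.4 percentage points higher (beyond the scatter) from compound 1 to compound 3 and a number 10.9 percentage points higher (beyond the scatter) from compound 2 to compound 4, 1.5 percentage points apart, within the scatter of two such steps.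

What the compounds shown leave open is whether a chain longer than dodecyl would change the number any further at this position. They also leave open how this end of the molecule would behave with a carboxylic acid, an amine or a phenyl ring in place of the straight alkyl chain.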